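The compounds below may be only part of what the source reports. "The series", "measured", "known", "first", "only" and "open" are said of these compounds alone.

Measured so far:
compound 1, `O=C(CCCCCCc1cccnc1)c1ncc(-c2ccccn2)o1`, 32 nM;
compound 2, `O=C(CCCCCSc1ccccc1)c1ncc(-c2ccccn2)o1`, 3 nM.

Both compounds were tested in an assay for inhibition of Fatty-acid amide hydrolase 1 (Rattus norvegicus) (on this read-out lower numbers stand for stronger inhibition and higher numbers for weaker inhibition), where compound 1 gives 32 nM and compound 2 gives 3 nM. Going by the values given here, compound 2 thus stands as the lowest of the two numbers, and the only measured step, an 11-fold lower number from compound 1 to compound 2 (1.03 log units; beyond the scatter), comes from exchanging the group at the end of the chain.

Compound 3, `O=C(CCCCCS(=O)(=O)c1ccccc1)c1ncc(-c2ccccn2)o1`, keeps that same position but carries phenylsulfonyl in place of phenylsulfanyl on a saturated chain carbon, five bonds along the chain from a carbonyl carbon. Among the compounds with values here, no measured step touches this particular exchange; the one known step only shows that the group at this chain end can move the number a great deal. Within the data shown here, with no direct precedent, a moderate rise in this assay is expected for compound 3, that is a 6.7-fold higher number from compound 2 to compound 3 (0.82 log units; beyond the scatter), with a wide range around it. The estimate for compound 3 is 20 nM, spanning from 5 nM to 80 nM.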

Compound 3, inhibition constant: 6000 nM
Beside the measured number, compound 3's estimate is 300-fold (2.48 log units) below it; measured number above the stated range.
By their numbers in this assay, from the lowest: compound 2; then compound 1; then compound 3.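

In this assay, changing phenylsulfanyl to phenylsulfonyl gives a 2000-fold higher number from compound 2 to compound 3 (3.30 log units; beyond the scatter), so this place on the chain responds strongly even when the phenyl ring stays and the change lies at the sulfur, where oxygens are added. Measured against the (pyridin-3-yl)methyl end group, phenylsulfonyl gives a 190-fold higher number from compound 1 to compound 3 (2.27 log units; beyond the scatter), which leaves it with the highest number of the three end groups shown. Nothing available here explains the size of this jump.

Still open, going by these compounds, is where a sulfoxide, with a single oxygen on the sulfur, or a phenoxy group, with an oxygen in place of the sulfur, would fall in this assay. On these data alone, it is also open whether phenylsulfonyl would give the same result on a longer chain.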